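Notes on the carbamate ester of the shared core

A few compounds are considered here, and "the series" means these few. Any claim that something is new, unique, unknown or untested is made for them only; others in the source may bear on it.

In an assay on cells for activation of Guanylate cyclase soluble subunit alpha-1 (Rattus norvegicus), read by cGMP accumulation and immunoassay, with a stated time of 10 min (a lower number here means that less compound is needed, a higher number that more compound is needed for the effect), compound 1 `COC(=O)N(Cc1ccc(F)cc1)c1c(N)nc(-c2nn(Cc3ccccc3F)c3ncccc23)nc1N` gives 0.7 uM. Compound 2 `COC(=O)Nc1c(N)nc(-c2nn(Cc3ccccc3F)c3ncccc23)nc1N` gives 0.3 uM in this assay, and compound 3 `Nc1nc(-c2nn(Cc3ccccc3F)c3ncccc23)nc(N)c1NC(=O)OC1CCC1` gives 0.2 uM. Compound 2 stands second highest of the three numbers: the step of a 2.3-fold lower number from compound 1 to compound 2 (0.37 log units; beyond the scatter) lies beyond the scatter, whereas the step of a 1.5-fold lower number from compound 2 to compound 3 (0.18 log units; within the scatter) stays within it. Compound 4 `Nc1nc(-c2nn(Cc3ccccc3F)c3ncccc23)nc(N)c1NC(=O)OCC(F)(F)F` differs from compound 2 by trifluoromethyl in place of hydrogen on a saturated chain carbon bound to an oxygen next to a carbonyl group. Within the data shown here, of the measured steps, the one from compound 2 to compound 3 alters the same oxygen-bound group, and its size a 1.5-fold lower number from compound 2 to compound 3 (0.18 log units; within the scatter) stays within the scatter; the change at the amide-type nitrogen in compound 1 bears less on it. A step of comparable size, downward if any, is expected, a 1.2-fold lower number from compound 2 to compound 4 (0.08 log units; within the scatter). Compound 4 is therefore estimated at 0.25 uM, with a range of 0.1 uM to 0.7 uM.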

Compound 4, minimum effective concentration: 0.2 uM
Compound 4: the middle estimate sits 1.3-fold (0.10 log units) above what was measured; low and high end bracket the measured number.
By their numbers in this assay, from the lowest: compounds 3, 4 and 2 (each within the scatter of the next); then compound 1.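

With trifluoromethyl in place of hydrogen on a saturated chain carbon bound to an oxygen next to a carbonyl group, the first fluorinated ester of the series holds its place in this assay (a 1.5-fold lower number from compound 2 to compound 4 (0.18 log units; within the scatter)). A ringless fluorinated group and a cyclobutyl ring also read alike here (no change at the digits printed from compound 3 to compound 4 (within the scatter)), so this ester position has so far accepted all three groups shown without a step beyond the scatter. Nothing available accounts for this sameness. As far as these compounds go, whether an ester group carrying an amine or a carboxylic acid would stay in this range remains open. So does the reading for a longer chain.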